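Benzofuran in Place of the Amide Aryl Group: Compound 4

The source may hold more compounds than are shown below. What is called first, only, known or untested is meant among the compounds shown, and "the series" means these compounds.

Compound 1 `CO[C@H]1CC[C@H](NC(=O)c2n[nH]cc2NC(=O)c2cnc3ccccn23)CC1` stands second highest of the three numbers in an ADME assay on MRC5 cells (Homo sapiens) for inhibition, with a stated time of 72 h (a lower number here means that less compound is needed, a higher number that more compound is needed for the effect), where compound 1 gives 5900 nM. For the measured compounds named here, compound 3 `CO[C@H]1CC[C@H](NC(=O)c2n[nH]cc2NC(=O)c2ccc(OC(F)F)cc2)CC1` gives 2500 nM, a lower number beyond the scatter, while compound 2 `CO[C@H]1CC[C@H](NC(=O)c2n[nH]cc2NC(=O)c2c(C)nc3ccccn23)CC1` gives 34000 nM; the only measured single-point step is a 5.8-fold higher number from compound 1 to compound 2 (0.76 log units; beyond the scatter), a methyl in place of hydrogen on an aromatic carbon. Compound 4 `CO[C@H]1CC[C@H](NC(=O)c2n[nH]cc2NC(=O)c2cc3ccccc3o2)CC1` is not yet measured. It differs from compound 1 in a group of 9 heavy atoms (8 carbon, 1 oxygen; one five-membered aromatic ring with 1 hetero atom, one six-membered aromatic ring of carbon only) in place of a group of 9 heavy atoms (7 carbon, 2 nitrogen; one five-membered aromatic ring with 2 hetero atoms, one six-membered aromatic ring with 1 hetero atom), on a carbonyl carbon, so the whole group on the carbonyl carbon is exchanged for 1-benzofuran-2-yl. Going by the values given here, no measured step bears directly on such an exchange: the step from compound 1 to compound 2 concerns a substituent on the group that leaves, not its replacement. Among the compounds with values here, the pair compound 1 and compound 3 shows only that a different group on the same carbonyl carbon yields the lower of the two numbers. Within the data shown here, with no direct precedent, a step of modest size in either direction is plausible, and the estimate leans toward a somewhat lower number. Compound 4 is expected at 3500 nM, with a range of 1200 nM to 10000 nM, which is an estimated step of a 1.7-fold lower number from compound 1 to compound 4 (0.23 log units; within the scatter).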

Compound 4, half-maximal effective concentration: 800 nM
Compound 4: middle estimate off by 4.4-fold (0.64 log units), on the high side; measured number below the stated range.
By their numbers in this assay, from the lowest: compound 4; then compound 3; then compound 1; then compound 2.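

For the compounds shown here, with compound 2, the only step on this carbonyl carbon's group was a methyl added to the group that leaves, and it raised the number; exchanging the whole group gives a 7.4-fold lower number from compound 1 to compound 4 (0.87 log units; beyond the scatter), so the number in this assay can move in either direction with what sits at this place. The exchange keeps the count of 9 heavy atoms and the five-membered and six-membered aromatic rings, while the two nitrogens give way to one oxygen and the hydrogen-bond acceptors drop from 2 to 1, so a change of this kind is enough for a step beyond the scatter. No measurement at hand accounts for the step.

On these data alone, it remains open whether the ring oxygen itself matters, which an indol-2-yl or benzothiophen-2-yl group on the same carbonyl carbon would test. Also open, as far as these compounds go, is how a methyl, chlorine or methoxy group on 1-benzofuran-2-yl would shift the number, given the step that methyl produced from compound 1 to compound 2.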